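Series note: acid-bearing chain on the core of compound 1

A few compounds are considered here, and "the series" means these few. Any claim that something is new, unique, unknown or untested is made for them only; others in the source may bear on it.

Going by the values given here, compound 1 `Cn1c(Cc2nn(C)c(=O)c3ccccc23)nnc1SCC(=O)Nc1ccc(Cl)cc1Cl` is the weaker of the two measured members: in an assay on 32D cells for inhibition of interleukin-15 (Mus musculus), read by resazurin assay, with stated times of 30 min and 2.5 days, in the presence of a further agent that is not named here (on this read-out higher numbers stand for weaker inhibition and lower numbers for stronger inhibition), compound 1 gives 22500 nM, the highest number recorded here. Compound 2 `Cn1nc(Cc2nnc(SCCCCCCCC(=O)Nc3ccc(Cl)cc3Cl)n2CCC=O)c2ccccc2c1=O` gives 2500 nM in this assay, a lower number that lies beyond the usual scatter; compound 2 differs from compound 1 in more than one place, so no single step can be read from the pair.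

Compound 3 `Cn1nc(Cc2nnc(SCC(=O)Nc3ccc(Cl)cc3Cl)n2CCC(=O)O)c2ccccc2c1=O` carries the change carboxymethyl in place of hydrogen on a saturated chain carbon bound to an aromatic nitrogen relative to compound 1, which reads, cut one bond further out, as methyl to 2-carboxyethyl. Among the compounds with values here, no measured pair shows this change in isolation. Because compound 2 at 2500 nM shows that a longer substituent at this position is tolerated in this assay, compound 3 is expected to move by a 1.5-fold lower number from compound 1 to compound 3 (0.18 log units; within the scatter), a small step toward a lower number, within or near the scatter. Compound 3 is estimated at 15000 nM, with a range from 4000 nM to 50000 nM.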

Compound 3, half-maximal inhibitory concentration: > 30000 nM
Compound 3: only a limit was reported (the forecaster's own chance of this, stated with the estimate: 15%); at least 2.0-fold (0.30 log units) between middle value and limit.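

In this assay compound 3 gives > 30000 nM as a limit of the assay and not as a number. Methyl to 2-carboxyethyl on the core of compound 1 gives an at least 1.3-fold higher number from compound 1 to compound 3 (0.12 log units; that floor lies within the scatter) and is the first change at this place that can be read alone, with no lower number for the acid-bearing chain. Going by these compounds, the full size of this step stays unknown, since the reading rests on a limit: the limit of > 30000 nM in this assay, at which 1 of the 3 values shown sits.

Compound 2 differs from compound 1 in more than one place, and its lower number is tied to no single place. Also open, on these data alone, are how far past the limit compound 3 lies, and how an amine or a methyl ester on the same chain, or a longer chain ending in a carboxylic acid, would read at this place.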